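A few compounds are considered here, and "the series" means these few. Any claim that something is new, unique, unknown or untested is made for them only; others in the source may bear on it.

In a functional assay for activation of Alpha-1D adrenergic receptor (Homo sapiens) (a lower number here means that less compound is needed, a higher number that more compound is needed for the effect), compound 1 `Cc1cc(-c2ccccc2NCC2=NCCN2)on1` reports only a limit of the assay, < 100000 nM, and not a number. Compound 2 `FC(F)(F)c1cccnc1-c1ccccc1NCC1=NCCN1` likewise gives only a limit in this assay, < 100000 nM. Compound 3 `CCO/N=C(\C)c1ccccc1NCC1=NCCN1` also shows only a limit in this assay, < 5020 nM. The change from compound 1 to compound 4 `CC/C(=N\OC)c1ccccc1NCC1=NCCN1` is a group of 6 heavy atoms (4 carbon, 1 nitrogen, 1 oxygen; no ring) in place of a group of 6 heavy atoms (4 carbon, 1 nitrogen, 1 oxygen; one five-membered aromatic ring with 2 hetero atoms), on an aromatic carbon. Among the compounds with values here, the one measured step that bears on it is a step that the two limits leave unreadable from compound 1 to compound 3, whose size cannot be read because compound 1 sits at the limit of < 100000 nM in this assay, at which 2 of the 3 values shown sit, while compound 3 sits at the limit of < 5020 nM in this assay, at which 1 of the 3 values shown sits. Compound 4 carries an open chain of the same kind as compound 3, so a move toward compound 3 is expected, its size unknown. Compound 4 is expected near 2000 nM, within 300 nM to 15000 nM, the expected step being a step that the limit leaves unreadable from compound 1 to compound 4.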

Compound 4, half-maximal effective concentration: < 100000 nM
Compound 4: no number, only a limit; the forecaster's own chance of this, stated with the estimate: 50%; the middle value lies beyond the limit too.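

Within the data shown here, compound 4 gives only a limit, as do compound 1 and compound 3, so no step among them can be read. The compounds shown leave open how much of each is actually needed in this assay.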